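Swapping an ethyl for a furanylmethyl on the ring nitrogen

This account rests on a few compounds, and the source may have more. Where it says the series, first, only, none or still open, it means among the compounds named here.

Of the compounds shown here, three sharing one core have been measured in an assay on cells for activation of Cystic fibrosis transmembrane conductance regulator (Homo sapiens), read by fluorescence, with a stated time of 10 min; a lower number here means that less compound is needed, a higher number that more compound is needed for the effect. Compound 1 `O=c1c(-c2cccc([N+](=O)[O-])c2)nc2c(Cl)cccc2n1Cc1ccccc1` gives 110 nM. Compound 2 `O=c1c(-c2cccc([N+](=O)[O-])c2)nc2cc(Cl)c(Cl)cc2n1Cc1ccccc1` reaches only the limit of the assay, > 10000 nM, so no number is known for it. Compound 3 `CCn1c(=O)c(-c2cccc([N+](=O)[O-])c2)nc2ccccc21`, which carries an ethyl group on the ring nitrogen of the shared core, gives 65 nM; this is the lowest of the two numbers shown, and its gap to compound 1 lies within the usual scatter, so the two cannot be ranked.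

Compound 4 `O=c1c(-c2cccc([N+](=O)[O-])c2)nc2ccccc2n1Cc1ccco1` has not been measured. It differs from compound 3 by furan-2-yl in place of methyl on a saturated chain carbon bound to an aromatic nitrogen. Compound 1 shows that a larger aromatic group on the same chain carbon is tolerated, and the step in this assay from compound 3 to compound 4 is expected to be small, a 1.5-fold higher number from compound 3 to compound 4 (0.19 log units; within the scatter), in either direction or none beyond the scatter. Compound 4 is therefore estimated at 100 nM, with a likely range from 30 nM to 400 nM.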

Compound 4, half-maximal effective concentration: 20 nM
The estimate for compound 4 lay 5.0-fold (0.70 log units) above the measured number; the whole stated range lies above it.
By their numbers in this assay, from the lowest: compound 4; then compounds 3 and 1 (each within the scatter of the next). At a limit, above all of these: compound 2.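

In this assay, putting furan-2-yl in place of methyl on a saturated chain carbon bound to an aromatic nitrogen gives a 3.3-fold lower number from compound 3 to compound 4 (0.51 log units; beyond the scatter), a modest step. Within the data shown here, this is the first comparison here between compounds that differ in one place, and it shows that the group at this position can change the number beyond the scatter, with the larger group giving the lower number. The compounds shown give no measurement that explains this step.

Going by these compounds, it remains open whether the step depends on the oxygen of the furan ring or would also appear with another ring on the same chain carbon, such as a thiophene or a plain phenyl on the unchlorinated core. Also open, on these data alone, is how an amine or a longer chain would fare at this position.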